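The source may hold more compounds than are shown below. What is called first, only, known or untested is meant among the compounds shown, and "the series" means these compounds.

Working notes. Among the measured compounds shown here, compound 2 `COc1cc(-n2cccc2C(=O)N2CCC(C)CC2)ccc1Nc1ncc(Cl)c(Nc2ccccc2NS(C)(=O)=O)n1` is one of two compounds measured in a functional assay on NCI-H2228 cells (Homo sapiens) for antiproliferative activity, read by MTT assay, with a stated time of 72 h; on this read-out lower numbers stand for stronger inhibition and higher numbers for weaker inhibition; in that assay compound 2 gives 1050 nM. The other is compound 1 `COC(=O)c1cccn1-c1ccc(Nc2ncc(Cl)c(Nc3ccccc3NS(C)(=O)=O)n2)c(OC)c1`, which in this assay gives 950 nM, and the step of a 1.1-fold higher number from compound 1 to compound 2 (0.04 log units; within the scatter) lies within the scatter, so compound 2 stands level with compound 1 rather than apart from it. Compound 3 `COc1cc(-n2cccc2C(=O)N(C)C)ccc1Nc1ncc(Cl)c(Nc2ccccc2NS(C)(=O)=O)n1` has not yet been measured. Its difference from compound 2 is dimethylamino in place of 4-methylpiperidin-1-yl on a carbonyl carbon. For the measured compounds named here, the only measured step that bears on this position is a 1.1-fold higher number from compound 1 to compound 2 (0.04 log units; within the scatter), where the group on the carbonyl carbon was exchanged without moving the number beyond the scatter. No comparator with dimethylamino exists in the series. The expectation for compound 3 in this assay is therefore a step of a 1.1-fold lower number from compound 2 to compound 3 (0.02 log units; within the scatter), not beyond the scatter. Compound 3 is estimated at 1000 nM, with a range from 500 nM to 2100 nM.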

Compound 3, half-maximal inhibitory concentration: 54 nM
Compound 3: the middle estimate sits 19-fold (1.27 log units) above what was measured; the measured number lies below the stated range.
By their numbers in this assay, from the lowest: compound 3; then compounds 1 and 2 (each within the scatter of the next).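

In this assay the group on the carbonyl carbon turns out not to be a silent position: the exchange for dimethylamino gives a 19-fold lower number from compound 2 to compound 3 (1.29 log units; beyond the scatter) when 4-methylpiperidin-1-yl leaves and an 18-fold lower number from compound 1 to compound 3 (1.25 log units; beyond the scatter) when methoxy leaves. Methoxy and 4-methylpiperidin-1-yl stood level with each other, so a carbonyl carrying a nitrogen group is not enough in itself, and among the three groups shown only dimethylamino sets its compound apart. Nothing measured here accounts for the size of this change.

Whether the lower number belongs to dimethylamino alone stays open, as the compounds shown do not cover neighbouring amines on this carbon, such as methylamino, diethylamino or pyrrolidin-1-yl. Nor do they show how a primary amide or a carboxylic acid at this place would compare.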